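The source may report more compounds than this note shows. Statements on the series, on what has been measured and on what is new or still open speak of the compounds shown alone.

Compound 1 `CCNC(=O)Nc1ccc(/C=C\c2cc(C)cc(C)c2)cc1` and compound 2 `Cc1cc(C)cc(/C=C\c2ccc(N3CCNC3=O)cc2)c1` share a core and differ in a single place, as do compound 3 `CCNC(=O)Nc1ccc(/C=C/c2cc(OC)c(OC)c(OC)c2)cc1` and the unmeasured compound 4 `COc1cc(/C=C/c2ccc(N3CCNC3=O)cc2)cc(OC)c1OC`. In a functional assay on M21 cells (Homo sapiens) for inhibition, read by sulforhodamine B assay, with a stated time of 48 h (a lower number here means a stronger inhibitor, a higher number a weaker inhibitor), compound 1 gives 16000 nM, while compound 2 gives 10 nM. The change between them is described as 2-oxoimidazolidin-1-yl in place of (ethylcarbamoyl)amino on an aromatic carbon and produced a 1600-fold lower number from compound 1 to compound 2 (3.20 log units; beyond the scatter). Compound 3 gives 29000 nM in this assay, the highest of the three measured numbers, and sits within the usual scatter of compound 1. The core of compound 3 differs from that of compound 1, but the difference between the two cores is not broken down here. The change from compound 3 to compound 4 is 2-oxoimidazolidin-1-yl in place of (ethylcarbamoyl)amino on an aromatic carbon, the same change at the same kind of position. Within the data shown here, because the one earlier example of this change gave a 1600-fold lower number from compound 1 to compound 2 (3.20 log units; beyond the scatter), a step of similar direction is expected for compound 4, though it rests on a single pair and a different core, so the expected size is taken more cautiously as a 580-fold lower number from compound 3 to compound 4 (2.76 log units; beyond the scatter). Compound 4 is therefore estimated at 50 nM in this assay, within a range from 8 nM to 500 nM.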

Compound 4, half-maximal inhibitory concentration: 550 nM
Beside the measured number, compound 4's estimate is 11-fold (1.04 log units) below it; measured number above the stated range.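

In this assay, replacing the open (ethylcarbamoyl)amino group with the ring-containing 2-oxoimidazolidin-1-yl group gives a 53-fold lower number from compound 3 to compound 4 (1.72 log units; beyond the scatter), so the number falls on this core as well. The direction of the change therefore carries from one core to the other, but its size does not: the same change on two cores in this assay, a 1600-fold lower number (3.20 log units; beyond the scatter) from compound 1 to compound 2 and a 53-fold lower number (1.72 log units; beyond the scatter) from compound 3 to compound 4, 30-fold (1.48 log units) apart, beyond the scatter of two such steps. These two pairs show that a step measured on one core cannot be copied directly to another, yet they do not show which difference between the cores goes with the smaller step, or why.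

From the compounds shown here alone, whether the same direction holds on further cores remains open, as two pairs cannot establish a general rule for the series. Also open, going by these compounds, is how this assay would respond to a propyl chain in place of the ethyl of the open group, or to a methyl group on the free nitrogen of the 2-oxoimidazolidin-1-yl ring.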